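A few compounds are considered here, and "the series" means these few. Any claim that something is new, unique, unknown or untested is made for them only; others in the source may bear on it.

Measured so far:
- compound 1 `COc1ccccc1-c1cn(-c2ccc(O)c(C(=O)Nc3cccc(C(F)(F)F)c3)c2)nn1`: 65%
- compound 2 `COc1ccc(OC)c(-c2cn(-c3ccc(O)c(C(=O)O)c3)nn2)c1`: 9%
- compound 3 `COc1ccccc1-c1cn(-c2ccc(O)c(C(=O)OCCCc3ccccc3)c2)nn1`: 4%

In a functional assay on CCRF-CEM cells (Homo sapiens) for inhibition, read by MTT assay, with a stated time of 2 days, tested at 10 uM (a higher number here means more inhibition at the concentration tested (going by the name of the read-out), a lower number less inhibition), compound 1 gives 65%, compound 2 gives 9%, and compound 3 gives 4%. Compound 3 sits at the bottom of the three numbers: compound 2 lies within the usual scatter of it, compound 1 lies beyond it. Among the measured compounds shown here, the one step between measured compounds that differ in a single place is a number 61 percentage points lower from compound 1 to compound 3 (beyond the scatter), and it concerns the group on the carbonyl carbon.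

The next compound, compound 4 `COc1ccccc1-c1cn(-c2ccc(O)c(C(=O)O)c2)nn1`, changes the same region once more: hydrogen in place of 3-phenylpropyl on an oxygen next to a carbonyl group. The large step from compound 1 to compound 3 already shows that this part of the shared core moves the read-out strongly, so a change here cannot be assumed to be neutral. Compound 2 carries the same hydrogen on the oxygen next to the carbonyl group and differs from compound 4 only elsewhere. In this assay compound 2 gives 9%, and this value and the value of compound 3 lie within the scatter of each other. No step beyond the scatter is therefore expected in this assay, the expected step being a number 3 percentage points higher from compound 3 to compound 4 (within the scatter). The value of compound 4 is therefore estimated at 7%, with a range from 0% to 20%.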

Compound 4, a percentage reported as inhibition, at one concentration (the size of the read-out at that concentration, not a potency): 9%
Compound 4: middle estimate off by 2 percentage points, on the low side; measured number inside the range.
By their numbers in this assay, from the lowest: compounds 3, 2 and 4 (each within the scatter of the next); then compound 1.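

In this assay, hydroxy and 3-phenylpropoxy on the carbonyl carbon are not separated, with a number 5 percentage points higher from compound 3 to compound 4 (within the scatter), so removing the 3-phenylpropyl group from the oxygen next to the carbonyl group neither restores nor further reduces the read-out. With a number 56 percentage points lower from compound 1 to compound 4 (beyond the scatter) alongside a number 61 percentage points lower from compound 1 to compound 3 (beyond the scatter), both replacements of (3-(trifluoromethyl)phenyl)amino on the carbonyl carbon fall beyond the scatter, which ties the higher read-out of this small set to that group rather than to one particular replacement. The methoxy on the aromatic carbon shows no effect in this low-reading acid pair, with no change at the digits printed from compound 2 to compound 4 (within the scatter), although this says nothing about that methoxy when (3-(trifluoromethyl)phenyl)amino is present.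

Nothing at hand bears on why the groups on the carbonyl carbon differ so widely. On these data alone, it remains open whether the read-out depends on the amide link or on the aromatic ring with its trifluoromethyl, a question that phenylamino, 3-chlorophenylamino and 3-phenylpropylamino on the same carbonyl carbon would begin to separate.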